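The source may hold more compounds than are shown below. What is called first, only, known or untested is meant among the compounds shown, and "the series" means these compounds.

Working notes on the series.

Compound 1 `O=C1COc2ccc(-c3cnc(Cl)c(NS(=O)(=O)c4ccc(F)cc4)c3)cc2N1c1ccccc1` is the reference point here. In a functional assay on HeLa cells (Homo sapiens) for antiproliferative activity, read by MTT assay, with a stated time of 72 h (a higher number here means a weaker inhibitor, a lower number a stronger inhibitor), compound 1 gives 10300 nM, the second highest of the three numbers recorded. Compound 2 `CC(C)N1C(=O)COc2ccc(-c3cnc(Cl)c(NS(=O)(=O)c4ccc(F)cc4)c3)cc21` gives 5380 nM in this assay; the step of a 1.9-fold lower number from compound 1 to compound 2 (0.28 log units; within the scatter) stays within the scatter. Compound 3 `Cc1ccc(N2C(=O)COc3ccc(-c4cnc(Cl)c(NS(=O)(=O)c5ccc(F)cc5)c4)cc32)cc1` gives 32300 nM in this assay; the step of a 3.1-fold higher number from compound 1 to compound 3 (0.50 log units; beyond the scatter) is modest but beyond the scatter, as is a 6.0-fold higher number from compound 2 to compound 3 (0.78 log units; beyond the scatter).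

Compound 4 `COc1ncc(-c2ccc3c(c2)N(c2ccccc2)C(=O)CO3)cc1NS(=O)(=O)c1ccc(F)cc1` is not yet measured. Relative to compound 1 the change is methoxy in place of chloro on an aromatic carbon. Every measured step in this set alters the group on the amide-type nitrogen in the ring or the aromatic carbon of that group; none touches the aromatic carbon that carries the chloro. For the measured compounds named here, no measured step therefore bears on this change, and nothing here predicts its direction. The working expectation is no step beyond the scatter in this assay, with a wide range to reflect the absence of a precedent. For compound 4 the estimate is 10000 nM, between 3000 nM and 35000 nM, which would mean an expected step of a 1.0-fold lower number from compound 1 to compound 4 (0.01 log units; within the scatter).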

Compound 4, half-maximal inhibitory concentration: 1530 nM
For compound 4 the middle estimate is 6.5-fold (0.82 log units) above the measured one; measured number outside the range, below it.
By their numbers in this assay, from the lowest: compound 4; then compounds 2 and 1 (each within the scatter of the next); then compound 3.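

For the compounds shown here, the replacement of chloro by methoxy gives a 6.7-fold lower number from compound 1 to compound 4 (0.83 log units; beyond the scatter) in this assay, the only step at this aromatic carbon, which lies next to the ring nitrogen and ortho to a ((4-fluorophenyl)sulfonyl)amino group. The earlier compounds shown here varied only the group on the amide-type nitrogen or the aromatic carbon of that group, whereas this result shows that the read-out also responds to the group at this position, with the lower number belonging to methoxy. No measurement on hand accounts for the step.

The compounds shown leave open whether the same change carries over when isopropyl or 4-methylphenyl sits on the amide-type nitrogen. They also leave open how an amine or a longer chain such as ethoxy at this carbon would compare with methoxy.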